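The source may hold more compounds than are shown below. What is called first, only, known or untested is meant among the compounds shown, and "the series" means these compounds.

Measured compounds:
- compound 1 `NC(=O)c1c(NC(=O)c2ccc(C(F)(F)F)cc2)sc2c1CCN(Cc1ccccc1F)C2` — in a functional assay on HL-60 cells (Homo sapiens) for antiproliferative activity, with a stated time of 24 h (on this read-out higher numbers stand for weaker inhibition and lower numbers for stronger inhibition), compound 1 gives > 50000 nM, a limit of the assay rather than a number.
- compound 2 `NC(=O)c1c(NC(=O)c2ccc(C(F)(F)F)cc2)sc2c1CCN(Cc1ccc(Cl)cc1Cl)C2` — in this assay compound 2 gives 14900 nM.

Within the data shown here, compound 2 holds the only numerical value; the other entry is a limit (the limit of > 50000 nM in this assay, at which 1 of the 2 values shown sits). Among the measured compounds shown here, the one measured step, an at least 3.3-fold lower number from compound 1 to compound 2 (0.52 log units; beyond the scatter), changes the group on the saturated chain carbon bound to the ring amine nitrogen and leaves the carbonyl-side aryl untouched.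

Compound 3 `NC(=O)c1c(NC(=O)c2cccc([N+](=O)[O-])c2)sc2c1CCN(Cc1ccc(Cl)cc1Cl)C2` differs from compound 2 only at that carbonyl-side aryl: 3-nitrophenyl in place of 4-(trifluoromethyl)phenyl on a carbonyl carbon. For the measured compounds named here, no measured step concerns this position, so the single measured step gives no direct guidance, and no change beyond the scatter is expected. Compound 3 is therefore estimated at 15000 nM (range 4000 nM to 50000 nM), corresponding to an expected step of a 1.0-fold higher number from compound 2 to compound 3 (0.00 log units; within the scatter).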

Compound 3, half-maximal inhibitory concentration: 19800 nM
Compound 3: middle estimate off by 1.3-fold (0.12 log units), on the low side; the range from low to high includes it.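

In this assay, replacing 4-(trifluoromethyl)phenyl with 3-nitrophenyl on the carbonyl carbon gives a 1.3-fold higher number from compound 2 to compound 3 (0.12 log units; within the scatter). Among these compounds, this is the first reading at the carbonyl-side aryl, and this exchange stays within the scatter, whereas the earlier step on the saturated chain carbon lay beyond it. The substituent and its printed ring position change together, and nothing here bears on why the read-out stays within the scatter.

Open, from the compounds shown here alone, is whether an amine or a carboxylic acid on this aryl, or a cyclohexyl group on the carbonyl carbon in place of the aryl, would also stay within the scatter. Also open, going by these compounds, is whether the same exchange would read alike with 2-fluorophenyl in place of 2,4-dichlorophenyl on the saturated chain carbon.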